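Working notes on oral exposure, compounds 2 and 3

The source may hold more compounds than are shown below. What is called first, only, known or untested is meant among the compounds shown, and "the series" means these compounds.

Measured so far:
compound 1 `CNC(=O)c1c(-c2ccc(F)cc2)oc2cc(-n3nccc3-c3ccc(B(O)O)c(F)c3)c(C3CC3)cc12` — 10000 ng.h/mL
compound 2 `CNC(=O)c1c(-c2ccc(F)cc2)oc2cc(N(Cc3ccc(B(O)O)c(F)c3)S(C)(=O)=O)c(C3CC3)cc12` — 700 ng.h/mL

In an ADME assay on the whole organism (Rattus norvegicus) for pharmacokinetics, read by LC-MS, at a dose of 5 mg/kg by the oral route (a lower number here means less compound in the circulation, a higher number more compound in the circulation at the dose given), compound 1 gives 10000 ng.h/mL, and compound 2 gives 700 ng.h/mL. Compound 2 stands lowest of the two numbers; its nearest neighbour is compound 1, whose number is higher by a margin beyond the scatter. Compound 3 `CNC(=O)c1c(-c2ccc(F)cc2)oc2cc(N(c3ccc(B(O)O)c(Cl)c3)S(C)(=O)=O)c(C3CC3)cc12` has not been measured in this assay. It differs from compound 2 in one place: a group of 10 heavy atoms (6 carbon, 1 boron, 2 oxygen, 1 chlorine; one six-membered aromatic ring of carbon only) in place of a group of 11 heavy atoms (7 carbon, 1 boron, 2 oxygen, 1 fluorine; one six-membered aromatic ring of carbon only), on a sulfonamide nitrogen. Going by the values given here, no step between measured compounds matches this change, so the two measured values say nothing about its direction. The step is estimated as a 1.3-fold higher number from compound 2 to compound 3 (0.11 log units; within the scatter), which is expected to stay within the scatter, with no direction asserted. Compound 3 is therefore expected to give 900 ng.h/mL in this assay, within a range of 250 ng.h/mL to 3000 ng.h/mL.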

Compound 3, area under the concentration-time curve: 4800 ng.h/mL
Compound 3: middle estimate off by 5.3-fold (0.73 log units), on the low side; measured number above the stated range.
By their numbers in this assay, from the lowest: compound 2; then compound 3; then compound 1.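

The group on the sulfonamide nitrogen strongly affects this assay: the change from the group holding fluorine to the group holding chlorine gives a 6.9-fold higher number from compound 2 to compound 3 (0.84 log units; beyond the scatter), a step beyond the scatter. Going by these compounds alone, the earlier compounds gave no readable step at this position, so this is the first sign that the number responds to a change made on this nitrogen. No measurement shown accounts for this step.

The compounds shown do not separate the part played by chlorine in place of fluorine from the part played by the change in carbon count, 6 against 7, within the group. As far as these compounds go, how this assay would respond to an amine or a carboxylic acid on the sulfonamide nitrogen also remains open.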